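This account rests on a few compounds, and the source may have more. Where it says the series, first, only, none or still open, it means among the compounds named here.

The three compounds measured so far, with their values in a functional assay on SMMC-7721 cells (Homo sapiens) for antiproliferative activity, read by MTT assay, with a stated time of 72 h; a higher number here means a weaker inhibitor, a lower number a stronger inhibitor:

compound 1, `CN(C(=O)c1ccccc1)c1ccc2[nH]c(-c3n[nH]c4ccccc34)cc2n1`: 12500 nM
compound 2, `CN(C(=O)c1ccc(F)cc1)c1ccc2[nH]c(-c3n[nH]c4ccccc34)cc2n1`: 9150 nM
compound 3, `CN(C(=O)c1ccc(Br)cc1)c1ccc2[nH]c(-c3n[nH]c4ccccc34)cc2n1`: 3460 nM

Among these, compound 3 gives the lowest number of the three in this assay, so it is the strongest inhibitor of the set; its nearest neighbour is compound 2, and the step of a 2.6-fold lower number from compound 2 to compound 3 (0.42 log units; beyond the scatter) lies beyond the scatter, as does a 3.6-fold lower number from compound 1 to compound 3 (0.56 log units; beyond the scatter). The step of a 1.4-fold lower number from compound 1 to compound 2 (0.14 log units; within the scatter), by contrast, stays within the scatter.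

Compound 4, `CN(c1ccc2[nH]c(-c3n[nH]c4ccccc34)cc2n1)S(=O)(=O)c1ccccc1`, differs from compound 3 in one place: phenylsulfonyl in place of (4-bromophenyl)carbonyl on a nitrogen on an aromatic ring. Two things change at once here. Within the data shown here, the bromine is lost, and none of the measured steps changes a carbonyl into a sulfonyl, so only the first part can be read against the data. Read backward, a 3.6-fold lower number from compound 1 to compound 3 (0.56 log units; beyond the scatter) suggests that removing the bromo substituent would move the number modestly upward, toward the level of compound 1. The sulfonyl part is unsupported by any measured pair, so the expected direction rests on the bromo alone, with a wide range.

Compound 4 is therefore expected to give about 9000 nM in this assay, most likely between 3000 nM and 30000 nM. That estimate means an expected step of a 2.6-fold higher number from compound 3 to compound 4 (0.42 log units; beyond the scatter).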

Compound 4, half-maximal inhibitory concentration: 12000 nM
The estimate for compound 4 lay 1.3-fold (0.12 log units) below the measured number, within the range that was stated.
By their numbers in this assay, from the lowest: compound 3; then compounds 2, 4 and 1 (each within the scatter of the next).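

In this assay, among these compounds, the pair with no ring substituent isolates the exchange of carbonyl for sulfonyl on this nitrogen for the first time, and a 1.0-fold lower number from compound 1 to compound 4 (0.02 log units; within the scatter) shows that the exchange leaves the number unresolved from that of the benzoyl compound. The fluorinated amide gives the same picture, with a 1.3-fold higher number from compound 2 to compound 4 (0.12 log units; within the scatter) also inside the scatter, whereas a 3.5-fold higher number from compound 3 to compound 4 (0.54 log units; beyond the scatter) is the only new step that clears it, so among these four compounds only the bromo amide stands apart and the sulfonyl offers no gain over the plain amide. No measurement shown here accounts for these values.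

From the compounds shown here alone, it remains open whether a bromo substituent on the phenylsulfonyl ring would lower the number as it does on the benzoyl ring, since the sulfonyl series is represented here only by its unsubstituted member. Also open, going by these compounds, is how other groups on that ring, such as chloro, methoxy or nitrile, or a plain methylene in place of the carbonyl on this nitrogen, would compare with the bromo amide.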